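The compounds below may be only part of what the source reports. "The series", "measured", "known", "first", "only" and "open" are said of these compounds alone.

Measured compounds:
Compound 1 `CC1=C(C(=O)Nc2ccc(F)cc2)C(c2ccc([N+](=O)[O-])cc2)N=C(SCc2ccccc2Cl)N1` gives 3.1%
Compound 2 `CC1=C(C(=O)Nc2ccc(F)cc2)C(c2ccc([N+](=O)[O-])cc2)N=C(SCc2cccc(Cl)c2)N1` gives 4.1%
Compound 3 `COc1ccc(C2N=C(SCc3ccccc3Cl)NC(C)=C2C(=O)Nc2ccc(Br)cc2)cc1` gives 4.6%

All three were tested in a functional assay on the whole organism (artery, strain albino) with Rattus norvegicus as the target, with a stated time of 30 min, at a dose of 10 mg/kg by the oral route; on this read-out higher numbers stand for more inhibition at the one dose given (going by the name of the read-out) and lower numbers for less inhibition. Compound 1 and compound 2 share one core and differ only by 3-chlorophenyl in place of 2-chlorophenyl on a saturated chain carbon bound to a sulfur; that change made the step of a number 1 percentage points higher from compound 1 to compound 2 (within the scatter). Compound 3 has a different core, and the difference between the two cores is not broken down here; its value lies within the scatter of both compound 1 and compound 2.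

Compound 4 `COc1ccc(C2N=C(SCc3cccc(Cl)c3)NC(C)=C2C(=O)Nc2ccc(Br)cc2)cc1` has not yet been measured. It differs from compound 3 by 3-chlorophenyl in place of 2-chlorophenyl on a saturated chain carbon bound to a sulfur, the same change that was made from compound 1 to compound 2 in this assay, at the same place. Because the earlier step of a number 1 percentage points higher from compound 1 to compound 2 (within the scatter) stayed within the scatter, the step of a number 0.9 percentage points higher from compound 3 to compound 4 (within the scatter) is expected to stay within the scatter as well, starting from the value of compound 3. Compound 4 is therefore estimated to give 5.5% in this assay, with a range from -4% to 15%, resting on a single prior step and so carrying a wide range.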

Compound 4, a percentage reported as inhibition, in the whole organism at one dose (the size of the read-out at that dose, not a potency): 7.7%
Estimate against measurement, compound 4: 2.2 percentage points below, within the range that was stated.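

In this assay, putting 3-chlorophenyl in place of 2-chlorophenyl on a saturated chain carbon bound to a sulfur gave a number 3.1 percentage points higher from compound 3 to compound 4 (within the scatter). Set beside the earlier case, the two results do not separate: the same change on two cores in this assay, a number 1 percentage points higher (within the scatter) from compound 1 to compound 2 and a number 3.1 percentage points higher (within the scatter) from compound 3 to compound 4, 2.1 percentage points apart, within the scatter of two such steps. Within the data shown here, this shows only that the change stayed within the scatter on both cores and that no dependence on the core can be seen in this pair of steps; it does not show that the change has a real effect on either core, nor that the same result would hold on a third core.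

The compounds shown leave open what happens at this place when the chlorine is exchanged for another group, such as an amine or a carboxylic acid. They also leave open whether a longer chain in place of the chlorobenzyl group would move the read-out beyond the scatter.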